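Ester swap from compound 2 to compound 3

This account rests on a few compounds, and the source may have more. Where it says the series, first, only, none or still open, it means among the compounds named here.

Going by the values given here, in a functional assay on A-375 cells (Homo sapiens) for cytotoxicity, read by MTT assay (a higher number here means a weaker inhibitor, a lower number a stronger inhibitor), compound 1 (`CCC(=O)Oc1cc(/C=C/C(=O)c2ccc(OC)c3c2OC(C)(C)C=C3)ccc1OC`) gives 240 nM and compound 2 (`COc1ccc(/C=C/C(=O)c2ccc(OC)c3c2OC(C)(C)C=C3)cc1OC(=O)c1ccc(Br)cc1`) gives 420 nM so the two stand within the scatter of each other, and compound 1 is the only neighbour of compound 2 on these numbers. The change now in view leads to compound 3 (`COc1ccc(/C=C/C(=O)Oc2cc(/C=C/C(=O)c3ccc(OC)c4c3OC(C)(C)C=C4)ccc2OC)cc1`) and reads 2-(4-methoxyphenyl)ethenyl in place of 4-bromophenyl on a carbonyl carbon with 2-(4-methoxyphenyl)ethenyl in place of 4-bromophenyl on a carbonyl carbon. Among the compounds with values here, one measured step bears on it, at the same place: a 1.8-fold higher number from compound 1 to compound 2 (0.24 log units; within the scatter) with 4-bromophenyl in place of ethyl on a carbonyl carbon. That exchange of a small chain for an aromatic ring stayed within the scatter. Within the data shown here, no measured compound carries the entering group, so this evidence is indirect and the range is kept wide. No step beyond the scatter is expected in this assay here. The expected change is a 1.2-fold lower number from compound 2 to compound 3 (0.08 log units; within the scatter) as an estimate only. For compound 3 the estimated value is 350 nM with an expected range from 130 nM to 950 nM in this series.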

Compound 3, half-maximal inhibitory concentration: 2630 nM
The estimate for compound 3 lay 7.5-fold (0.88 log units) below the measured number; the measured number lies above the stated range.
By their numbers in this assay, from the lowest: compounds 1 and 2 (each within the scatter of the next); then compound 3.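

In this assay, the group on the carbonyl carbon proves to matter: 2-(4-methoxyphenyl)ethenyl in place of 4-bromophenyl gives a 6.3-fold higher number from compound 2 to compound 3 (0.80 log units; beyond the scatter), whereas the exchange of ethyl for 4-bromophenyl had stayed within the scatter. The same entering group in place of ethyl gives an 11-fold higher number from compound 1 to compound 3 (1.04 log units; beyond the scatter), so compound 3 stands apart from both compound 1 and compound 2, and the tolerance seen at this position does not extend to every group that carries an aromatic ring. 4-bromophenyl and 2-(4-methoxyphenyl)ethenyl each hold one six-membered aromatic ring of carbon only, yet compound 2 and compound 3 still differ beyond the scatter, and no measurement at hand accounts for that step.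

The compounds shown do not separate the parts of the entering group: its double bond outside the aromatic ring, its oxygen and its larger count of heavy atoms all change together. Plain 2-phenylethenyl and 4-methoxyphenyl on the same carbonyl carbon would each isolate one of these parts, and whether the step follows the double bond or the methoxy group remains open.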